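The source may report more compounds than this note shows. Statements on the series, on what has been measured and on what is new or still open speak of the compounds shown alone.

Compound 1, `Cc1cccc(C)c1S(=O)(=O)N1CCC[C@H]1[C@@H](O)CN1CCC[C@@]2(CCN(c3ncnc(N)c3C3CC3)C2)C1`, gives 9 nM in an assay on isolated protein for inhibition of RAC-alpha serine/threonine-protein kinase (Homo sapiens); a lower number here means a stronger inhibitor, a higher number a weaker inhibitor.
Compound 2, `Cc1cccc(C)c1S(=O)(=O)N1CCC[C@@H]1[C@@H](O)CN1CCC[C@@]2(CCN(c3ncnc(N)c3C3CC3)C2)C1`, gives 19 nM in this assay.
Compound 3, `Nc1ncnc(N2CC[C@@]3(CCCN(C[C@H](O)CNS(=O)(=O)c4ccccc4F)C3)C2)c1C1CC1`, gives 81 nM in this assay.

Compound 3 stands highest of the three numbers in this assay; compound 2 is the nearest to it and compound 1 the furthest, both at lower numbers. Compound 4, `Cc1cc(F)ccc1S(=O)(=O)NC[C@@H](O)CN1CCC[C@@]2(CCN(c3ncnc(N)c3C3CC3)C2)C1`, has not yet been measured. The change from compound 3 to compound 4 is 4-fluoro-2-methylphenyl in place of 2-fluorophenyl on a sulfonyl sulfur. Among the compounds with values here, the only measured step, a 2.1-fold higher number from compound 1 to compound 2 (0.32 log units; beyond the scatter), concerns a change of configuration alone, as seen from the fact that compounds 1 and 2 differ only in the configuration as drawn, and it leaves the aryl group on the sulfonyl sulfur untouched. Within the data shown here, compounds 1 and 2 carry a different aryl group and a different linker from compound 3, so their values show only that those two compounds sit at lower numbers; no measured step isolates the aryl group on the sulfonyl sulfur. The expectation for compound 4 in this assay is therefore a step of no more than the scatter, a 1.2-fold lower number from compound 3 to compound 4 (0.06 log units; within the scatter), with no firm direction. Compound 4 is estimated at 70 nM, within a range from 25 nM to 200 nM.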

Compound 4, half-maximal inhibitory concentration: 8 nM
The estimate for compound 4 lay 8.8-fold (0.94 log units) above the measured number, and the stated range ends above it.
By their numbers in this assay, from the lowest: compounds 4 and 1 (each within the scatter of the next); then compound 2; then compound 3.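

The aryl group on the sulfonyl sulfur proves to be a position to which this assay responds strongly: with the rest of the structure held the same, 4-fluoro-2-methylphenyl in place of 2-fluorophenyl brings a 10-fold lower number from compound 3 to compound 4 (1.01 log units; beyond the scatter) in a single exchange. Within the data shown here, the earlier compounds could not show this, as their one measured step concerned configuration alone and left this aryl group untouched, while compounds 1 and 2 differ from compound 3 in more than one place. The entering group is only one carbon heavier than the group it replaces. Nothing at hand gives a cause for the step.

The step also cannot be divided between the two features of the entering group, as the compounds shown include neither a 2-methylphenyl nor a 4-fluorophenyl on the sulfonyl sulfur to separate the methyl from the shifted fluorine. Nor do they show how the number moves with other groups on this ring, such as a chlorine, a methoxy or a nitrile.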